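The source may report more compounds than this note shows. Statements on the series, on what has been measured and on what is new or still open speak of the compounds shown alone.

Measured in an ADME assay on MT4 cells (Homo sapiens) for cytotoxicity, read by MTT assay; on this read-out higher numbers stand for lower toxicity in this test and lower numbers for higher toxicity in this test:
- Compound 1 `Cc1ccc(N(C(=O)c2ccccc2[N+](=O)[O-])C(=S)OCCN2C(=O)c3ccccc3C2=O)cc1`: 100000 nM
- Compound 2 `COc1cccc(OC)c1C(=O)N(C(=S)OCCN1C(=O)c2ccccc2C1=O)c1ccc(C)cc1`: 36000 nM

Compound 2 holds the lower of the two numbers, so it is the more toxic of this pair. Compound 3 `Cc1ccc(N(C(=O)c2ccc(Cl)c([N+](=O)[O-])c2)C(=S)OCCN2C(=O)c3ccccc3C2=O)cc1` awaits measurement. It differs from compound 2 by 4-chloro-3-nitrophenyl in place of 2,6-dimethoxyphenyl on a carbonyl carbon, with 4-chloro-3-nitrophenyl in place of 2,6-dimethoxyphenyl on a carbonyl carbon. Going by the values given here, only one measured step bears on this: a 2.8-fold lower number from compound 1 to compound 2 (0.44 log units; beyond the scatter), where 2,6-dimethoxyphenyl replaced 2-nitrophenyl. Here 2,6-dimethoxyphenyl leaves for another nitro-bearing ring, so a modest rise is expected, although no measured compound carries the chlorine. The expected step is a 1.5-fold higher number from compound 2 to compound 3 (0.18 log units; within the scatter). Compound 3 is estimated at 55000 nM, with a range of 18000 nM to 100000 nM.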

Compound 3, half-maximal cytotoxic concentration: 47000 nM
For compound 3 the middle estimate is 1.2-fold (0.07 log units) above the measured one; the range from low to high includes it.
By their numbers in this assay, from the lowest: compounds 2 and 3 (each within the scatter of the next); then compound 1.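

In this assay the carbonyl carbon takes 4-chloro-3-nitrophenyl in place of 2,6-dimethoxyphenyl with a 1.3-fold higher number from compound 2 to compound 3 (0.12 log units; within the scatter) and so shows no real separation between these two rings. The same ring in place of 2-nitrophenyl gives a 2.1-fold lower number from compound 1 to compound 3 (0.33 log units; beyond the scatter) and so shows that having a nitro group on the ring does not alone preserve the number of compound 1. Nothing available explains these differences.

Open, going by these compounds, is whether a ring carrying an amine or a carboxylic acid would shift the number at this place. Also open, on these data alone, is what chlorine does without the nitro group.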